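This account rests on a few compounds, and the source may have more. Where it says the series, first, only, none or still open, it means among the compounds named here.

Compound 1 `C#CCOc1ccccc1/C=N/Cc1ccc(S(N)(=O)=O)cc1`: 31000 nM
Compound 2 `C#CCOc1cccc(/C=N/Cc2ccc(S(N)(=O)=O)cc2)c1`: 104000 nM
Compound 3 `C#CCOc1ccc(/C=N/Cc2ccc(S(N)(=O)=O)cc2)cc1`: 14100 nM

In a functional assay on HT-29 cells (Homo sapiens) for cytotoxicity, read by MTT assay, with a stated time of 24 h (a lower number here means a stronger inhibitor, a higher number a weaker inhibitor), compound 1 stands in the middle of these three. Compound 3 gives a lower number and compound 2 a higher one, and both gaps lie beyond the usual scatter. The next compound is compound 4 `C#CCOc1c(/C=N/Cc2ccc(S(N)(=O)=O)cc2)cccc1OC`, which differs from compound 1 in one place: methoxy in place of hydrogen on an aromatic carbon. This is methoxy in place of hydrogen on an aromatic carbon, ortho to a propargyloxy group. For the measured compounds named here, no measured pair shows a change of this kind, so no step beyond the scatter is expected in this assay, and the uncertainty is wide. The expected change is a 1.1-fold lower number from compound 1 to compound 4 (0.04 log units; within the scatter). For compound 4 the estimated value is 28000 nM, with an expected range of 10000 nM to 80000 nM.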

Compound 4, half-maximal inhibitory concentration: 81300 nM
For compound 4 the middle estimate is 2.9-fold (0.46 log units) below the measured one, outside the stated range (above it).
By their numbers in this assay, from the lowest: compound 3; then compound 1; then compounds 4 and 2 (each within the scatter of the next).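

In this assay, methoxy in place of hydrogen on an aromatic carbon, ortho to a propargyloxy group, gives a 2.6-fold higher number from compound 1 to compound 4 (0.42 log units; beyond the scatter). This is the only change in a single place among these compounds, and it shows that this carbon is not indifferent to substitution: the added methoxy weakens the effect beyond the usual scatter. Nothing given here accounts for the size or direction of this step. On these data alone, whether a hydroxyl group or a fluorine atom on the same carbon would move the number the same way remains open.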